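Dihydrofuran carboxamides: no cytotoxicity readable so far

The source may hold more compounds than are shown below. What is called first, only, known or untested is meant among the compounds shown, and "the series" means these compounds.

Three compounds on a shared core have been run in a functional assay on HeLa cells (Homo sapiens) for cytotoxicity, read by MTT assay, with a stated time of 24 h; on this read-out higher numbers stand for weaker inhibition and lower numbers for stronger inhibition. Compound 2 `C=CC1=C(C(=O)Nc2ccccc2)C(c2ccc(Cl)c(Cl)c2)OC1` carries a phenyl on the amide nitrogen and a 3,4-dichlorophenyl on the saturated ring carbon. In this assay compound 2 gives only a limit, > 100000 nM. Compound 1 `C=CC1=C(C(=O)NCCCCC)C(c2ccc(Cl)c(Cl)c2)OC1` differs from compound 2 by pentyl in place of phenyl on an amide-type nitrogen. In this assay compound 1 likewise gives only a limit, > 100000 nM. The step that the two limits leave unreadable from compound 2 to compound 1 therefore has no readable size. Compound 3 `C=CC1=C(C(=O)Nc2ccccc2)C(c2ccc(F)cc2)OC1` keeps the phenyl amide of compound 2 but carries a 4-fluorophenyl on the saturated ring carbon. In this assay compound 3 also gives only a limit, > 100000 nM. The step that the two limits leave unreadable from compound 2 to compound 3 is equally unreadable; the whole picture rests on (the limit of > 100000 nM in this assay, at which 3 of the 3 values shown sit).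

Compound 4 `C=CC1=C(C(=O)NCCCCC)C(c2ccc(F)cc2)OC1` has not been measured. It differs from compound 3 by pentyl in place of phenyl on an amide-type nitrogen, the same change as that from compound 2 to compound 1, made on a core that differs from the core of compound 2 by 4-fluorophenyl in place of 3,4-dichlorophenyl on a saturated ring carbon. Since that earlier change could not be sized and all three measured compounds sit at the limit, compound 4 is expected to sit there too, with an expected step that the limit leaves unreadable from compound 3 to compound 4. For compound 4 in this assay an estimate of 200000 nM is given, between 100000 nM and 1000000 nM, most likely reported only as a limit.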

Compound 4, half-maximal inhibitory concentration: > 100000 nM
Compound 4: only a limit was reported; the forecaster's own chance of this, stated with the estimate: 85%; the middle value is on the limit's open side.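

Compound 3 and compound 4 both give only a limit, so no step between them can be read, and the change from phenyl to pentyl on an amide-type nitrogen remains unsized: the limit of > 100000 nM in this assay, at which 4 of the 4 values shown sit.

The compounds shown leave open whether any change on the shared core gives a readable cytotoxicity value, and how large the effect of either substituent change is.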